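Solubility notes: spiro lactam replaced by methoxyethyl amide

A few compounds are considered here, and "the series" means these few. Any claim that something is new, unique, unknown or untested is made for them only; others in the source may bear on it.

Measured compounds:
compound 1 `CN(C)Cc1ccc2c(c1)CN(c1cnc(NCc3c(F)ccc4c3CCO4)c3cn[nH]c(=O)c13)C2=O` gives 174000 nM in a physicochemical assay for solubility, read by LC-MS, in phosphate buffer, with a stated time of 24 h, at pH 7.4; on this read-out lower numbers stand for lower solubility and higher numbers for higher solubility
compound 2 `O=C1CC2(CC2)CN1c1cnc(NCc2c(F)ccc3c2CCO3)n2cnnc12` gives 130000 nM in this assay

Within the data shown here, compound 2 holds the lower of the two numbers, and compound 1 is its only neighbour; the gap between them falls within the scatter, so no order is drawn from it. Compound 3 `COCCC(=O)Nc1cnc(NCc2c(F)ccc3c2CCO3)n2cnnc12` is not yet measured. It differs from compound 2 in one place: a group of 7 heavy atoms (4 carbon, 1 nitrogen, 2 oxygen; no ring) in place of a group of 8 heavy atoms (6 carbon, 1 nitrogen, 1 oxygen; one three-membered non-aromatic ring of carbon only, one five-membered non-aromatic ring with 1 hetero atom), on an aromatic carbon. Among the measured compounds shown here, no step between measured compounds is known. A small rise in this assay is expected, close to the scatter, as a 1.5-fold higher number from compound 2 to compound 3 (0.16 log units; within the scatter). Compound 3 is estimated at 190000 nM, with a range from 70000 nM to 500000 nM.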

Compound 3, solubility: 980000 nM
Compound 3: the middle estimate sits 5.2-fold (0.71 log units) below what was measured, outside the stated range (above it).
By their numbers in this assay, from the lowest: compounds 2 and 1 (each within the scatter of the next); then compound 3.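

At this aromatic carbon, the open ((2-methoxyethyl)carbonyl)amino group in place of the ring-bearing lactam gives a 7.5-fold higher number from compound 2 to compound 3 (0.88 log units; beyond the scatter) in this assay. Among these compounds, this is the first step that can be read, and it shows that the number at this position moves with this one change on the shared core. Nothing available bears on why the number rises.

Which part of the new group carries the step stays open. A plain propionyl amide, a longer ether chain or a terminal amine at this carbon would separate the amide hydrogen from the ether oxygen.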